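Series notes: aryl swap on the saturated ring carbon

The compounds below may be only part of what the source reports. "The series", "measured", "known", "first", "only" and "open" are said of these compounds alone.

Compound 3 `O=CCN1N=C(c2ccc3ccccc3c2)CC1c1cccc(Cl)c1Cl` gives 17900 nM in a functional assay on PC-3 cells (Homo sapiens) for cytotoxicity, read by sulforhodamine B assay, with a stated time of 48 h (a lower number here means a stronger inhibitor, a higher number a weaker inhibitor), the highest of the three numbers; compound 1 `COc1ccc(C2CC(c3ccco3)=NN2C(C)=O)cc1OC` gives 12300 nM, within the scatter of compound 3, while compound 2 `O=CCN1N=C(c2ccc3ccccc3c2)CC1c1ccccc1[N+](=O)[O-]` gives 3010 nM, beyond it. Compound 4 `COc1ccc(C2CC(c3ccc4ccccc4c3)=NN2CC=O)cc1O` differs from compound 3 only in 3-hydroxy-4-methoxyphenyl in place of 2,3-dichlorophenyl on a saturated ring carbon. For the measured compounds named here, the one measured step that bears on this site, a 5.9-fold higher number from compound 2 to compound 3 (0.77 log units; beyond the scatter), shows a change of the aryl group there moving the number beyond the scatter. Compound 1, carrying a related dimethoxyphenyl on a different core, gave its number in the same region as compound 3, so no large shift is expected. The estimate for compound 4 is 9000 nM (range 3000 nM to 27000 nM), an expected step of a 2.0-fold lower number from compound 3 to compound 4 (0.30 log units; within the scatter).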

Compound 4, half-maximal inhibitory concentration: 2040 nM
Compound 4: the middle estimate sits 4.4-fold (0.64 log units) above what was measured; measured number outside the range, below it.
By their numbers in this assay, from the lowest: compounds 4 and 2 (each within the scatter of the next); then compounds 1 and 3 (each within the scatter of the next).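

The site responds strongly to the aryl group: an 8.8-fold lower number from compound 3 to compound 4 (0.94 log units; beyond the scatter) is a larger move than the earlier step at this carbon, and it runs in the opposite direction in number. For the compounds shown here, with a 1.5-fold lower number from compound 2 to compound 4 (0.17 log units; within the scatter), the 3-hydroxy-4-methoxyphenyl and 2-nitrophenyl groups cannot be told apart here, leaving 2,3-dichlorophenyl as the one aryl group of the three with a clearly higher number. No measurement on hand explains these shifts.

From the compounds shown here alone, whether the hydroxy or the methoxy group of compound 4 alone carries the step remains open. So does where an amine or a carboxylic acid on this aryl ring would fall.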